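This account rests on a few compounds, and the source may have more. Where it says the series, first, only, none or still open, it means among the compounds named here.

Notes on the series. Compound 1 `C=CC(=O)NCCCCCCCCCCCCCC` gives 21400 nM in an assay on HEK293T cells for inhibition of palmitoyltransferase ZDHHC20 (Homo sapiens), read by fluorescence polarization, with stated times of 1 h, 1 min and 2 h, in the presence of a further agent that is not named here; on this read-out higher numbers stand for weaker inhibition and lower numbers for stronger inhibition. For the measured compounds named here, compound 2 `C#CCOC(=O)/C=C\C(=O)NCCCCCCCCCCCCCC` gives 3430 nM in this assay and holds the lowest of the two numbers so far, separated from compound 1 by the step of a 6.2-fold lower number from compound 1 to compound 2 (0.80 log units; beyond the scatter). Compound 3 `CCCCCCCCCCCCCCNC(=O)/C=C\C(=O)OCC#N` differs from compound 2 by cyano in place of ethynyl on a saturated chain carbon bound to an oxygen next to a carbonyl group; cut one bond further out, the same difference reads propargyloxycarbonyl to cyanomethoxycarbonyl. Going by the values given here, no measured step bears on this exchange: the only step available, a 6.2-fold lower number from compound 1 to compound 2 (0.80 log units; beyond the scatter), concerns the replacement of vinyl on a carbonyl carbon and is no guide to a swap at the far end of the ester. With nothing comparable to lean on, a change beyond the scatter is not expected in either direction. Compound 3 is expected to show a 1.0-fold higher number from compound 2 to compound 3 (0.01 log units; within the scatter) in this assay. Compound 3 is estimated at 3500 nM, with a range from 1200 nM to 10000 nM.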

Compound 3, half-maximal inhibitory concentration: 2870 nM
Estimate against measurement, compound 3: 1.2-fold (0.09 log units) above, and the stated range covers the measured number.
By their numbers in this assay, from the lowest: compounds 3 and 2 (each within the scatter of the next); then compound 1.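

In this assay, the exchange of ethynyl for cyano on a saturated chain carbon bound to an oxygen next to a carbonyl group gives a 1.2-fold lower number from compound 2 to compound 3 (0.08 log units; within the scatter), so this read-out does not separate the propargyl and cyanomethyl esters, even though cyano brings a hydrogen-bond acceptor that ethynyl lacks. The advantage over the vinyl amide therefore survives this exchange: a 7.5-fold lower number from compound 1 to compound 3 (0.87 log units; beyond the scatter) sits alongside a 6.2-fold lower number from compound 1 to compound 2 (0.80 log units; beyond the scatter), and both steps lie beyond the scatter. Nothing available explains why the two groups read alike.

Still open, from the compounds shown here alone, is whether this end of the molecule accepts a real departure from these two small groups, such as a carboxylic acid or a phenyl ester in place of propargyloxycarbonyl. Going by these compounds, the effect of a shorter chain on the amide also remains open.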